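The source may report more compounds than this note shows. Statements on the series, on what has been measured and on what is new or still open speak of the compounds shown alone.

Compound 3, with the structure `CC1=CC(=O)/C(=C(/C)Nc2ccc3c(cnn3C)c2)C(=O)O1`, is measured in an ADME assay on RAW264.7 cells (Mus musculus) for cytotoxicity, read by resazurin assay, with a stated time of 48 h; a higher number here means that more compound is tolerated, a lower number that less compound is tolerated. Compound 3 reaches only the limit of that assay, at > 100000 nM, so no number is known for it. Compound 4, with the structure `C=CCn1ncc2cc(N/C(C)=C3\C(=O)C=C(C)OC3=O)ccc21`, has not yet been measured; it differs from compound 3 by vinyl in place of hydrogen on a saturated chain carbon bound to an aromatic nitrogen.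

Within the data shown here, one measured step bears on this change. Compound 1, with the structure `CCn1nc(Cl)c2ccc(N/C(C)=C3\C(=O)C=C(C)OC3=O)cc21`, gives 6230 nM in this assay. Compound 2, with the structure `C=CCn1nc(Cl)c2ccc(N/C(C)=C3\C(=O)C=C(C)OC3=O)cc21`, reaches only the limit of this assay, at > 100000 nM. The change from compound 1 to compound 2 is the same exchange of methyl for allyl, and it raised the tolerated amount by an at least 16-fold higher number from compound 1 to compound 2 (1.20 log units; beyond the scatter). The evidence here is thin, because the limit of > 100000 nM in this assay, at which 2 of the 3 values shown sit, means most of what is known is a limit rather than a number.

Since the same change once moved the number up beyond the scatter, and compound 3 already sits at that limit, compound 4 is expected to stay at the limit as well, with the step from compound 3 to compound 4 estimated as a number no higher from compound 3 to compound 4 (the limit leaves the size open). Compound 4 is therefore expected to give about 100000 nM in this assay, somewhere between 30000 nM and 300000 nM.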

Compound 4, half-maximal cytotoxic concentration: > 100000 nM
Compound 4 was reported as a limit; the forecaster's own chance of this, stated with the estimate: 85%; the middle value lies on the limit itself.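

Among these compounds, compound 3 and compound 4 both sit at the limit of this assay, so no step between them can be read. The compounds shown leave open how much of compound 3 or compound 4 the cells actually tolerate, and so whether adding vinyl changes anything here, since most of what is known is a limit: the limit of > 100000 nM in this assay, at which 3 of the 4 values shown sit.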